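From methylbenzyl to nitrobenzyl: compound 4 awaits measurement

The source may report more compounds than this note shows. Statements on the series, on what has been measured and on what is new or still open speak of the compounds shown alone.

The measured compounds, each with its value in an assay on CHO cells for displacement of a labelled ligand from Alpha-1B adrenergic receptor (Homo sapiens); a higher number here means a weaker inhibitor, a lower number a stronger inhibitor:
compound 1, `COc1cccc(OC)c1OCCNCCOc1ccccc1OCc1ccccc1`, gives 0.537 nM
compound 2, `COc1cccc(OC)c1OCCNCCOc1ccccc1OCc1cccc(C)c1`, gives 0.251 nM
compound 3, `COc1cccc(OC)c1OCCNCCOc1ccccc1OCc1ccc(C)cc1`, gives 0.251 nM

Compound 3 stands level with compound 2 at the digits printed, and the two share the lowest numbers of the three; one measured step is a 2.1-fold lower number from compound 1 to compound 3 (0.33 log units; beyond the scatter), and the other is a 2.1-fold lower number from compound 1 to compound 2 (0.33 log units; beyond the scatter). Between the two methyl isomers the step is no change at the digits printed from compound 2 to compound 3 (within the scatter).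

Compound 4, `COc1cccc(OC)c1OCCNCCOc1ccccc1OCc1cccc([N+](=O)[O-])c1`, differs from compound 3 in one place: 3-nitrophenyl in place of 4-methylphenyl on a saturated chain carbon bound to an oxygen on an aromatic ring. The measured steps that bear on this position are both methyl-for-hydrogen exchanges, each a modest gain, and the move of the methyl from one position to the other left the number unchanged. Among the compounds with values here, no measured step shows what a 3-nitrophenyl does in place of a 4-methylphenyl here, so the direction of the change is open. For compound 4 the estimate is therefore set near the range spanned by compounds 1 to 3, with a step of a 2.4-fold higher number from compound 3 to compound 4 (0.38 log units; beyond the scatter) expected in this assay. Compound 4 is expected to give about 0.6 nM, within a range from 0.2 nM to 2 nM.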

Compound 4, inhibition constant: 0.794 nM
Compound 4: middle estimate off by 1.3-fold (0.12 log units), on the low side, and the stated range covers the measured number.
By their numbers in this assay, from the lowest: compounds 2 and 3 (each within the scatter of the next); then compounds 1 and 4 (each within the scatter of the next).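

In this assay, the methyl and nitro groups part ways at this position: 3-nitrophenyl in place of 4-methylphenyl on the saturated chain carbon gives a 3.2-fold higher number from compound 3 to compound 4 (0.50 log units; beyond the scatter), and nitro in place of methyl on an aromatic carbon gives a 3.2-fold higher number from compound 2 to compound 4 (0.50 log units; beyond the scatter), so the advantage held by both methyl isomers does not carry over to the nitro group. Nitro in place of hydrogen, by contrast, gives a 1.5-fold higher number from compound 1 to compound 4 (0.17 log units; within the scatter), which lies within the scatter, so unlike either methyl group, the nitro group cannot be told apart from the unsubstituted benzyl of compound 1, and the ring carries the larger group without a step beyond the scatter from that parent. Nothing shown here accounts for the different outcomes with methyl and nitro.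

Going by these compounds, the series holds only one nitro isomer, so it remains open whether moving that group on the ring would leave the number unchanged, as moving the methyl did. On these data alone, what an amine, a carboxylic acid or a methoxy group would do on this ring also remains open, as does whether a second methyl would add to the step seen with one.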